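Nitro for Methoxy on Two Cores at a Nicotinic Receptor

The source may report more compounds than this note shows. Statements on the series, on what has been measured and on what is new or still open speak of the compounds shown alone.

Three compounds were measured in an assay on cell membranes for displacement of a labelled ligand from Neuronal acetylcholine receptor; alpha4/beta2 (Rattus norvegicus); on this read-out lower numbers stand for stronger inhibition and higher numbers for weaker inhibition:

Compound 1, `COc1ccc(Nc2cncc(N3CC4CC(C3)N4)c2)cc1`: 0.0598 nM
Compound 2, `O=[N+]([O-])c1ccc(Nc2cncc(N3CC4CC(C3)N4)c2)cc1`: 0.0225 nM
Compound 3, `COc1ccc(Nc2ccc(N3CC4CC(C3)N4)nn2)cc1`: 578 nM

Compound 1 and compound 2 share one core, and compound 3 has another; the difference between the two cores is not broken down here. Compound 3 stands far from the other two: its number in this assay lies well above that of compound 1 and further still above that of compound 2.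

Within the first core a single change has been made, (nitro in place of methoxy on an aromatic carbon), and it gave a 2.7-fold lower number from compound 1 to compound 2 (0.42 log units; beyond the scatter). Compound 4, `O=[N+]([O-])c1ccc(Nc2ccc(N3CC4CC(C3)N4)nn2)cc1`, carries the same change on the core of compound 3, namely (nitro in place of methoxy on an aromatic carbon). The place is the same in both pairs, so this is the same change, seen twice in all among these compounds.

Since the change on the first core gave a 2.7-fold lower number from compound 1 to compound 2 (0.42 log units; beyond the scatter), a step of like size is expected here, a 2.8-fold lower number from compound 3 to compound 4 (0.44 log units; beyond the scatter), though the gap from compound 3 to the other two is so wide that the second core may not follow the first. Compound 4 is therefore estimated to give 210 nM in this assay, within 70 nM to 650 nM.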

Compound 4, inhibition constant: 86.2 nM
Estimate against measurement, compound 4: 2.4-fold (0.39 log units) above; low and high end bracket the measured number.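

On the second core, nitro in place of methoxy again lowered the number in this assay, giving a 6.7-fold lower number from compound 3 to compound 4 (0.83 log units; beyond the scatter). Set beside the step on the first core, it points the same way, and the two sizes cannot be told apart: the same change on two cores in this assay, a 2.7-fold lower number (0.42 log units; beyond the scatter) from compound 1 to compound 2 and a 6.7-fold lower number (0.83 log units; beyond the scatter) from compound 3 to compound 4, 2.5-fold (0.40 log units) apart, within the scatter of two such steps. For these two pairs, then, the change carried over from one core to the other even though the cores themselves sit at very different levels, but two pairs make no general rule for this series, and they say nothing about what separates the two cores.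

The compounds shown leave open how other groups would behave at the same place on the carbon-only aromatic ring, such as an amine, a carboxylic acid or a nitrile, since only methoxy and nitro appear there. Also open, as far as these compounds go, is whether a third core would follow the same step, or whether it would hold in any read-out other than this binding measurement.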